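The source may report more compounds than this note shows. Statements on the series, on what has been measured and on what is new or still open speak of the compounds shown alone.

Measured compounds:
- compound 1 `C#Cc1cccc(Nc2ncnc3cc(NC(=O)/C=C/c4ccccc4)sc23)c1`: 700 nM
- compound 2 `O=C(/C=C/c1ccccc1)Nc1cc2ncnc(Nc3cc(Cl)cc(Cl)c3)c2s1`: 220 nM
- compound 3 `C#Cc1cccc(Nc2ncnc3sc(NC(=O)/C=C/c4ccccc4)cc23)c1`: 400 nM

In a functional assay on PC-3 cells (Homo sapiens) for antiproliferative activity, read by MTT assay, with a stated time of 48 h (a lower number here means a stronger inhibitor, a higher number a weaker inhibitor), compound 1 gives 700 nM and compound 2 gives 220 nM. For the measured compounds named here, the step of a 3.2-fold lower number from compound 1 to compound 2 (0.50 log units; beyond the scatter) is the one change made in this pair: 3,5-dichlorophenyl in place of 3-ethynylphenyl on a nitrogen on an aromatic ring. Compound 3 has the same atoms as compound 1 joined differently; the difference between the two cores is not broken down here. In this assay compound 3 gives 400 nM, which lies within the scatter of compound 1 and of compound 2, so no order among these three is claimed.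

Compound 4 `O=C(/C=C/c1ccccc1)Nc1cc2c(Nc3cc(Cl)cc(Cl)c3)ncnc2s1` is not yet measured. It stands to compound 3 as compound 2 stands to compound 1: 3,5-dichlorophenyl in place of 3-ethynylphenyl on a nitrogen on an aromatic ring. The place lines of the two changes read the same word for word, so this is the same kind of change on a different core.

Going by the values given here, for compound 4 the step is expected to be about a 2.9-fold lower number from compound 3 to compound 4 (0.46 log units; beyond the scatter), resting on the single measured step of a 3.2-fold lower number from compound 1 to compound 2 (0.50 log units; beyond the scatter), with wider uncertainty because only one such step is known and the core of compound 3 differs. Compound 4 is therefore expected to give 140 nM in this assay, between 60 nM and 350 nM.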

Compound 4, half-maximal inhibitory concentration: 390 nM
Estimate against measurement, compound 4: 2.8-fold (0.44 log units) below; measured number above the stated range.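

In this assay, putting 3,5-dichlorophenyl in place of 3-ethynylphenyl on a nitrogen on an aromatic ring gives a 1.0-fold lower number from compound 3 to compound 4 (0.01 log units; within the scatter), so on this core the exchange leaves no readable difference. The result of the exchange on one core therefore does not carry over to the other in this series, and the size of the step depends on which core bears it: the same change on two cores in this assay, a 3.2-fold lower number (0.50 log units; beyond the scatter) from compound 1 to compound 2 and a 1.0-fold lower number (0.01 log units; within the scatter) from compound 3 to compound 4, 3.1-fold (0.49 log units) apart, beyond the scatter of two such steps

This rests on a single pair per core, so it shows that the step is not transferable between these two cores, but not what separates them, nor how the exchange would behave on any further core. On these data alone, whether the gap between the two steps persists with other groups on that nitrogen, such as a methoxyphenyl or a pyridine ring, stays open. Also open, as far as these compounds go, is whether it persists when the phenyl ring of the amide chain carries an amine or a carboxylic acid.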